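This account rests on a few compounds, and the source may have more. Where it says the series, first, only, none or still open, it means among the compounds named here.

Compound 1 `CC1=C(C(=O)OC(C)(C)C)C(c2cccs2)NC(=O)N1`: 7%. Compound 2 `CC1=C(C(=O)OCc2ccccc2)C(c2cccs2)NC(=O)N1`: 8%. Compound 3 `CCNC(=O)C1=C(C)NC(=O)NC1c1cccs1`: 4%.

These three share one core and differ only in the group on the carbonyl carbon. In an assay on membranes from HeLa cells for displacement of a labelled ligand from adenosine receptor A3 (Homo sapiens), read by scintillation counting, with a stated time of 180 min, tested at 1 uM (a higher number here means more inhibition at the concentration tested (going by the name of the read-out), a lower number less inhibition), all three give small numbers, and compound 3, bearing ethylamino, lies within the scatter of compound 1 and of compound 2, so it cannot be set apart from either. Compound 4 `CC1=C(C(=O)OC2CCCC2)C(c2cccs2)NC(=O)N1` carries cyclopentyloxy in place of ethylamino on a carbonyl carbon. For the measured compounds named here, two measured steps bear on this change: a number 1 percentage points higher from compound 1 to compound 2 (within the scatter) and a number 3 percentage points lower from compound 1 to compound 3 (within the scatter), both within the scatter. Swapping groups on this carbon has so far moved nothing beyond the scatter, so for compound 4 no step beyond the scatter is expected in this assay, a number 3 percentage points higher from compound 3 to compound 4 (within the scatter). Compound 4 is therefore estimated at 7%, between 0% and 18%.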

Compound 4, a percentage reported as inhibition, at one concentration (the size of the read-out at that concentration, not a potency): 1%
For compound 4 the middle estimate is 6 percentage points above the measured one; the measured number falls inside the stated range.
By their numbers in this assay, from the lowest: compounds 4, 3, 1 and 2 (each within the scatter of the next).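

Adding a non-aromatic carbon ring on the oxygen still does not set this series apart in this assay: the steps to cyclopentyloxy are all within the scatter (a number 3 percentage points lower from compound 3 to compound 4 (within the scatter); a number 7 percentage points lower from compound 2 to compound 4 (within the scatter); a number 6 percentage points lower from compound 1 to compound 4 (within the scatter)). Ethylamino, tert-butoxy, benzyloxy and cyclopentyloxy on this carbonyl carbon therefore cannot be told apart here, whether the group holds a ring or not. Nothing available explains this lack of separation.

Still open, going by these compounds, is whether a carboxylic acid at this carbon, or a longer chain on the amide nitrogen, would give a step beyond the scatter.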